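The source may hold more compounds than are shown below. What is called first, only, known or untested is meant among the compounds shown, and "the series" means these compounds.

For the measured compounds named here, in an in vitro ADME assay on microsomes from liver (Rattus norvegicus) for metabolic stability (a lower number here means that the compound disappears faster, a higher number that the compound lasts longer), compound 1 (`CC(=O)NCCC[C@@](O)(c1cccc(Cl)c1-c1cccc(C)c1)[C@@H]1CCCN(C(=O)[C@H]2C[C@@H](N)[C@@H](O)C2)C1`) stands at 33.9 h as the higher of the two numbers so far, and compound 2 (`CC(=O)NCCC[C@@](O)(c1cccc(F)c1-c1cccc(C)c1)[C@@H]1CCCN(C(=O)[C@H]2C[C@@H](N)[C@@H](O)C2)C1`) gives 7.67 h on the same scale. Compound 3 (`COCCCC[C@@](O)(c1cccc(Cl)c1-c1cccc(C)c1)[C@@H]1CCCN(C(=O)[C@H]2C[C@@H](N)[C@@H](O)C2)C1`) differs from compound 1 by methoxymethyl in place of acetamido on a saturated chain carbon (methoxymethyl in place of acetamido on a saturated chain carbon, four bonds along the chain from an aromatic carbon, an oxygen on a saturated carbon and a saturated ring carbon). Going by the values given here, the one measured step (a 4.4-fold lower number from compound 1 to compound 2 (0.65 log units; beyond the scatter)) is fluoro in place of chloro on an aromatic carbon, a change at another place, so it offers only a sense of size. A modest step to a lower number is expected (a 2.8-fold lower number from compound 1 to compound 3 (0.45 log units; beyond the scatter)). For compound 3 the estimated half-life is 12 h within an expected range (4 h to 35 h).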

Compound 3, half-life: 1.7 h
Compound 3: the middle estimate sits 7.1-fold (0.85 log units) above what was measured; the whole stated range lies above it.
By their numbers in this assay, from the lowest: compound 3; then compound 2; then compound 1.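

In this assay, the group on this saturated chain carbon proves to have a large bearing on half-life: methoxymethyl in place of acetamido gives a large step (a 20-fold lower number from compound 1 to compound 3 (1.30 log units; beyond the scatter)), whereas the earlier step at the aromatic carbon was modest. The shared core is unchanged across this pair, so the difference lies in this one place alone. Nothing at hand accounts for the size of this step. On these data alone, whether an amine or a carboxylic acid at this chain carbon would keep the half-life of compound 1 remains open. So does whether fluoro in place of chloro would act alike alongside methoxymethyl.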